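A few compounds are considered here, and "the series" means these few. Any claim that something is new, unique, unknown or untested is made for them only; others in the source may bear on it.

Compound 3 `Cc1[nH]c2ccccc2c1C(C1=C(O)C(=O)c2ccccc2C1=O)c1ccc([N+](=O)[O-])cc1` gives 4570 nM in a functional assay on HeLa cells (Homo sapiens) for cytotoxicity, read by MTT assay, with a stated time of 48 h (on this read-out higher numbers stand for weaker inhibition and lower numbers for stronger inhibition), the lowest of the three numbers; compound 1 `COc1cc(C(C2=C(O)C(=O)c3ccccc3C2=O)c2c[nH]c3ccc(Br)cc23)cc(OC)c1OC` gives 9710 nM and compound 2 `O=C1C(O)=C(C(c2ccc([N+](=O)[O-])cc2)c2c[nH]c3ccccc23)C(=O)c2ccccc21` gives 14800 nM. Compound 4 `O=C1C(O)=C(C(c2ccc([N+](=O)[O-])cc2)c2c[nH]c3ccc(Br)cc23)C(=O)c2ccccc21` differs from compound 3 by 5-bromo-1H-indol-3-yl in place of 2-methyl-1H-indol-3-yl on a saturated chain carbon bound to an aromatic carbon and a double-bonded ring carbon. Going by the values given here, the one step that bears on this is a 3.2-fold lower number from compound 2 to compound 3 (0.51 log units; beyond the scatter), the methyl on the aromatic carbon; compound 4 lacks that methyl and instead carries bromine, for which no paired step exists, though compound 1 with the same bromo-indole stands near compound 3. The removal of the methyl is therefore expected to undo most of that gain, giving an estimated 2.2-fold higher number from compound 3 to compound 4 (0.34 log units; beyond the scatter). Compound 4 is expected at 10000 nM, within 4000 nM to 25000 nM.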

Compound 4, half-maximal inhibitory concentration: 14100 nM
Compound 4: the middle estimate sits 1.4-fold (0.15 log units) below what was measured; the range from low to high includes it.
By their numbers in this assay, from the lowest: compound 3; then compounds 1, 4 and 2 (each within the scatter of the next).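

Going by these compounds alone, with bromo as the only change, the step reads a 1.0-fold lower number from compound 2 to compound 4 (0.02 log units; within the scatter) in this assay, so this bromine alone shows no measurable gain, and the lower number of compound 3 stays tied to its 2-methyl-1H-indol-3-yl group, with 5-bromo-1H-indol-3-yl in its place giving a 3.1-fold higher number from compound 3 to compound 4 (0.49 log units; beyond the scatter). With the bromo group held, 4-nitrophenyl in place of 3,4,5-trimethoxyphenyl gives a 1.5-fold higher number from compound 1 to compound 4 (0.16 log units; within the scatter) and so also stays inside the scatter. No evidence is available to explain these steps. Still open, as far as these compounds go, is whether methyl and bromo together on one compound would add up, and how an amine on that aromatic carbon would read.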